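The source may hold more compounds than are shown below. What is called first, only, known or untested is meant among the compounds shown, and "the series" means these compounds.

Measured compounds: compound 1 `CC/C=C\[C@H](C)[C@H](OC(N)=O)[C@@H](C)[C@H](O)[C@@H](C)C/C(C)=C\[C@H](C)[C@@H](O)[C@@H](C)/C=C\[C@@H](O)C[C@@H]1OC(=O)[C@H](C)[C@@H](O)[C@H]1C` and compound 2 `CC/C=C\[C@H](C)[C@H](OC(N)=O)[C@@H](C)[C@H](O)[C@@H](C)C/C(C)=C\[C@H](C)[C@@H](O)[C@@H](C)/C=C\[C@@H](O)C[C@H](O)[C@H](C)CO`.

In a functional assay on A549 cells (Homo sapiens) for antiproliferative activity (on this read-out lower numbers stand for stronger inhibition of growth and higher numbers for weaker inhibition of growth), compound 1 gives "not determined" (no result reported), so no number places it. In this assay compound 2 gives 5000 nM; no difference between compound 1 and compound 2 is set out here, so nothing can be read from that pair. Compound 3 `CC/C=C\[C@H](C)[C@H](OC(N)=O)[C@@H](C)[C@H](O)[C@@H](C)C/C(C)=C\[C@H](C)[C@@H](O)[C@@H](C)/C=C\[C@@H](O)C[C@@H]1OC(=O)[C@H](C)[C@@H](OC)[C@H]1C` follows from compound 1 by methyl in place of hydrogen on an oxygen on a saturated carbon. For the measured compounds named here, without a value for compound 1 and with no measured step of this kind, the direction of this change in this assay is open; the estimate for compound 3 is 1500 nM, expected to lie between 100 nM and 20000 nM.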

Compound 3, concentration for 50% growth inhibition: 12 nM
Estimate against measurement, compound 3: 130-fold (2.10 log units) above; the measured number lies below the stated range.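

In this assay, for the compounds shown here, the step of a 420-fold lower number from compound 2 to compound 3 (2.62 log units; beyond the scatter) gives the first measured comparison at this position: a six-membered non-aromatic ring carrying the methoxy group, in place of the open chain group, goes with much stronger growth inhibition, well beyond the scatter. No supporting data on the cause of this large step are available here.

With no number for compound 1, the step from hydroxy to methoxy cannot be read on its own. As far as these compounds go, whether an ethoxy group or an amine at this position would keep that potency remains open.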